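The compounds below may be only part of what the source reports. "The series", "measured", "known", "first", "only" and "open" are said of these compounds alone.

Measured so far in a functional assay on the whole organism (strain CF-1) with Mus musculus as the target; on this read-out higher numbers stand for an effect only at larger amounts of compound and lower numbers for an effect already at smaller amounts:
- compound 1 `Cc1nnc(CN2CCCC2)n1-c1ccc(Cl)cc1Cc1ccccc1`: 40 mg/kg
- compound 2 `CN(C)Cc1nnc(-c2ccco2)n1-c1ccc(Cl)cc1C(=O)c1ccccc1`: 28 mg/kg
- compound 3 `Cc1nnc(CN)n1-c1ccc(Cl)cc1C(O)c1ccccc1`: 2.8 mg/kg

Within this set compound 2 holds the second highest of the three numbers. Its nearest neighbour is compound 1, whose number lies higher but within the scatter, so no order between compound 1 and compound 2 can be read from these two values. Compound 3 stands well apart, its number lower by a margin beyond the scatter.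

The next compound, compound 4 `Cc1nnc(CN(C)C)n1-c1ccc(Cl)cc1C(=O)c1ccccc1`, is derived from compound 2 by a single change: methyl in place of furan-2-yl on an aromatic carbon. The (dimethylamino)methyl group and the benzoyl-type carbonyl on the core are kept.

Within the data shown here, no pair of measured compounds differs in exactly this way, so no measured step is available. Compound 1 and compound 3 both carry the methyl at this position and give numbers on either side of compound 2, which gives no clear direction for the change. The step from compound 2 to compound 4 is therefore expected to be small, a 1.4-fold lower number from compound 2 to compound 4 (0.15 log units; within the scatter), likely not beyond the scatter. For compound 4 in this assay the estimated value is 20 mg/kg, with a range from 6 mg/kg to 60 mg/kg.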

Compound 4, dose for half-maximal effect: 2.2 mg/kg
The estimate for compound 4 lay 9.1-fold (0.96 log units) above the measured number, and the stated range ends above it.
By their numbers in this assay, from the lowest: compounds 4 and 3 (each within the scatter of the next); then compounds 2 and 1 (each within the scatter of the next).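

In this assay the exchange of furan-2-yl for methyl, with the (dimethylamino)methyl group and the carbonyl kept, gives a 13-fold lower number from compound 2 to compound 4 (1.10 log units; beyond the scatter) and so shows that this aromatic carbon of the five-membered aromatic ring with 3 nitrogen is sensitive to what it carries. The earlier compounds shown here could not show this, as none of them formed a one-place pair at this position, whereas this pair isolates the position and sets the two groups clearly apart in this read-out. Nothing measured here accounts for the size of the step, so the pair gives a direction and a magnitude but no cause.

The pair leaves open whether the gap is specific to furan-2-yl or follows more generally from a ring or from the heavy-atom count at this position, which hydrogen, ethyl, phenyl or thiophen-2-yl there would help to separate. It also leaves open whether the same exchange gives a step of similar size when the (dimethylamino)methyl group gives way to a primary aminomethyl or pyrrolidin-1-ylmethyl group.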